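Swapping the Ring on the Ketone of Compound 3

The source may report more compounds than this note shows. Statements on the series, on what has been measured and on what is new or still open speak of the compounds shown alone.

All four compounds share one core and differ only in the ring attached to the carbonyl. Compound 1 `COc1ccc(C(=O)c2sc(NC(C)C)c(C#N)c2N)cc1` and compound 2 `COc1ccc(C(=O)c2sc(NC(C)C)c(C#N)c2N)cc1OC` carry the same kind of ring there, compound 3 `CC(C)Nc1sc(C(=O)c2ccncc2)c(N)c1C#N` a pyridin-4-yl, and compound 4 `CC(C)Nc1sc(C(=O)c2ccc(Cl)s2)c(N)c1C#N` a 5-chlorothiophen-2-yl. In an assay for inhibition of Maternal embryonic leucine zipper kinase (Homo sapiens), read by ADP-Glo, with a stated time of 0.5 h (on this read-out higher numbers stand for weaker inhibition and lower numbers for stronger inhibition), compound 1 gives 4130 nM, while compound 2 gives 1770 nM; the step of a 2.3-fold lower number from compound 1 to compound 2 (0.37 log units; beyond the scatter) comes from a methoxy in place of hydrogen on an aromatic carbon. For compound 3 this assay reports only a limit, > 5000 nM, and that is where it stands (the limit of > 5000 nM in this assay, at which 1 of the 3 values shown sits).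

The change to compound 4 is 5-chlorothiophen-2-yl in place of pyridin-4-yl on a carbonyl carbon. For the measured compounds named here, no measured step exchanges a whole ring on the carbonyl; the only measured step, a 2.3-fold lower number from compound 1 to compound 2 (0.37 log units; beyond the scatter), adds a methoxy to a ring that stays in place, and it is modest. What the shown numbers do say is that compounds with other rings on this carbonyl, such as compound 1 and compound 2, give numbers rather than a limit, so the ring matters. Because compound 3 sits at > 5000 nM, a number for compound 4 would register as a gain. Compound 4 is expected near 3500 nM, within 1200 nM to 15000 nM. The step this expectation implies is an at least 1.4-fold lower number from compound 3 to compound 4 (0.15 log units; that floor lies within the scatter).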

Compound 4, half-maximal inhibitory concentration: 192 nM
Compound 4: the middle estimate sits 18-fold (1.26 log units) above what was measured, and the stated range ends above it.
By their numbers in this assay, from the lowest: compound 4; then compound 2; then compound 1. At a limit, above all of these: compound 3.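

For the compounds shown here, this is the only measured exchange of a whole ring on the carbonyl carbon, and in this assay it gives an at least 26-fold lower number from compound 3 to compound 4 (1.41 log units; beyond the scatter), which shows that this position responds much more strongly to a change of ring than to the added methoxy in a 2.3-fold lower number from compound 1 to compound 2 (0.37 log units; beyond the scatter). The change is large even though pyridin-4-yl and 5-chlorothiophen-2-yl have equal counts of heavy atoms, hydrogen-bond donors and hydrogen-bond acceptors and neither carries a net charge, so those counts alone do not tell the two rings apart. The step gives a floor and not an exact size, since one end of it is a limit rather than a number: the limit of > 5000 nM in this assay, at which 1 of the 4 values shown sits.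

From the compounds shown here alone, it remains open whether the chlorine, the thiophene ring or the two together account for the change, a question that a plain thiophen-2-yl on the same carbonyl carbon could help to settle. Also open, going by these compounds, is how this position would respond to a 5-chlorothiophen-2-yl with its chlorine replaced by a methyl group, an amine or a carboxylic acid.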